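A few compounds are considered here, and "the series" means these few. Any claim that something is new, unique, unknown or untested is made for them only; others in the source may bear on it.

Compound 1, `O=C(O)CC(Cc1nc2cc(Cl)ccc2[nH]1)c1ccc(Cl)cc1`, in an assay on isolated protein for inhibition of protein kinase C zeta type (Homo sapiens), read by 33P incorporation, tested at 200 uM; on this read-out lower numbers stand for a weaker effect and higher numbers for a stronger effect at the one concentration tested: 70%.
Compound 2, `COc1ccc2[nH]c(CC(CC(=O)O)c3ccc(Cl)cc3)nc2c1`, in this assay: 0%.

Compound 2 gives the lowest of the two numbers, and its nearest neighbour, compound 1, lies far above it. Compound 3, `O=C(O)CC(Cc1nc2cc(C(=O)O)ccc2[nH]1)c1ccc(Cl)cc1`, differs from compound 2 in one place: carboxy in place of methoxy on an aromatic carbon. Among the measured compounds shown here, one measured step touches this same position: a number 70 percentage points lower from compound 1 to compound 2 (beyond the scatter), which shows that the group there can swing the read-out strongly. For the measured compounds named here, no measured step compares carboxy with methoxy, so the direction of the new step is uncertain, and only a modest change is expected: a number 15 percentage points higher from compound 2 to compound 3 (beyond the scatter). Compound 3 is therefore estimated at 15%, within a range from 0% to 45%.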

Compound 3, a percentage reported as inhibition, at one concentration (the size of the read-out at that concentration, not a potency): 0%
Estimate against measurement, compound 3: 15 percentage points above; low and high end bracket the measured number.
By their numbers in this assay, from the lowest: compounds 2 and 3 (each within the scatter of the next); then compound 1.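

Putting carboxy in place of methoxy on this aromatic carbon gives no change at the digits printed from compound 2 to compound 3 (within the scatter) in this assay, so two quite different groups now share the same low reading. Against chloro, the same carboxy group gives a number 70 percentage points lower from compound 1 to compound 3 (beyond the scatter), which leaves chloro as the only one of the three groups here with a clear reading at this position. Nothing available explains this difference. As far as these compounds go, whether other groups at this carbon keep the effect of chloro remains open, for example fluoro, bromo, methyl or an amine.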